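Working notes on the series: from compound 3 to compound 4

The source may report more compounds than this note shows. Statements on the series, on what has been measured and on what is new or still open speak of the compounds shown alone.

Compound 1 `COc1ccc(-c2ncc(C(=O)O)c(=O)[nH]2)cc1`: > 5 mg/kg, a limit of the assay
Compound 2 `CCOc1ccc(Cl)cc1-c1ncc(C(=O)O)c(=O)[nH]1`: 0.5 mg/kg
Compound 3 `CCOC(=O)c1cnc(-c2cc(Cl)ccc2OCC)[nH]c1=O`: 0.5 mg/kg

In a functional assay on the whole organism (strain Sprague-Dawley) for inhibition, with Rattus norvegicus as the target, with a stated time of 10 min (on this read-out higher numbers stand for an effect only at larger amounts of compound and lower numbers for an effect already at smaller amounts), compound 1 reaches only a limit, > 5 mg/kg, as noted in the limit of > 5 mg/kg in this assay, at which 1 of the 3 values shown sits. Compound 3 gives 0.5 mg/kg and stands level with compound 2, which gives 0.5 mg/kg; the step of no change at the digits printed from compound 2 to compound 3 (within the scatter) lies within the scatter. Compound 4 `CCOC(=O)c1cnc(-c2cc(S(=O)(=O)N(C)C)ccc2OCC)[nH]c1=O` differs from compound 3 by dimethylsulfamoyl in place of chloro on an aromatic carbon. Among the compounds with values here, no measured step concerns the chloro; the only step known, no change at the digits printed from compound 2 to compound 3 (within the scatter), involves the ester and is flat. From the compounds shown here alone, the dimethylsulfamoyl group is untested, so the expectation for compound 4 is a modest shift toward larger doses, a 2.0-fold higher number from compound 3 to compound 4 (0.30 log units; within the scatter). Compound 4 is estimated at 1 mg/kg, with a range from 0.3 mg/kg to 5 mg/kg.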

Compound 4, dose for 50% inhibition: 50 mg/kg
The estimate for compound 4 lay 50-fold (1.70 log units) below the measured number; the measured number lies above the stated range.
By their numbers in this assay, from the lowest: compounds 2 and 3 (each within the scatter of the next); then compound 4.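

In this assay, dimethylsulfamoyl in place of chloro gives a 100-fold higher number from compound 3 to compound 4 (2.00 log units; beyond the scatter), the only step shown that lies beyond the scatter. The aromatic carbon para to an ethoxy group therefore weighs far more on the dose than the ester does, whose step reads no change at the digits printed from compound 2 to compound 3 (within the scatter). Nothing in the data at hand accounts for the size of this step. Open, from the compounds shown here alone, is whether fluoro, methoxy or an unsubstituted sulfonamide at this carbon stays level with compound 3. Also open, going by these compounds, is whether the carboxylic acid carrying dimethylsulfamoyl follows compound 4.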